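The compounds below may be only part of what the source reports. "The series", "measured", "known", "first", "only" and "open" are said of these compounds alone.

Working notes on the series. Among the compounds with values here, compound 1 `COc1cc(/C=C/C(=O)C2=C(/C=C/c3ccc(O)c(OC)c3)NC(=O)NC2c2ccccc2Cl)ccc1O` and compound 2 `COc1cc(/C=C/C(=O)C2=C(/C=C/c3ccc(O)c(OC)c3)NC(=S)NC2c2ccccc2)ccc1O` share one core and differ from each other in two places, so no single step is drawn between them. In a functional assay, with a stated time of 20 min, tested at 2 uM (on this read-out higher numbers stand for a stronger effect at the one concentration tested and lower numbers for a weaker effect), compound 1 gives 16.6%. In this assay, within the data shown here, compound 2 gives 16.6%, level with compound 1 at the digits printed and within the scatter, so the two values show no difference between these compounds.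

Compound 3 `COc1cc(/C=C/C(=O)C2=C(/C=C/c3ccc(O)c(OC)c3)NC(=S)NC2c2ccc(N(C)C)cc2)ccc1O` is the next member, not yet measured. It differs from compound 2 in one place: dimethylamino in place of hydrogen on an aromatic carbon. Among the measured compounds shown here, no step between measured compounds bears on this kind of change, so nothing here points to a step beyond the scatter in either direction. The expected step in this assay is a number 0.4 percentage points higher from compound 2 to compound 3 (within the scatter), that is, none beyond the scatter. Compound 3 is estimated to give 17% in this assay, with a range from 5% to 32%.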

Compound 3, a percentage reported as activity, at one concentration (the size of the read-out at that concentration, not a potency): 32.3%
Estimate against measurement, compound 3: 15.3 percentage points below; measured number outside the range, above it.
By their numbers in this assay, from the lowest: compounds 1 and 2 (each within the scatter of the next); then compound 3.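

Dimethylamino in place of hydrogen on an aromatic carbon, para to a large group, gives a number 15.7 percentage points higher from compound 2 to compound 3 (beyond the scatter) in this assay, so this position on the ring responds to substitution. Within the data shown here, this is the only single-place step so far, as compounds 1 and 2 differ in two places and could not show what one change at this position does. The measurements shown offer no account of why the number rises.

On these data alone, whether a primary amine, a methoxy group or a carboxylic acid in the same place gives a step of similar size stays open, as does the effect of dimethylamino elsewhere on this ring. Also open, as far as these compounds go, is whether the step carries over to compounds with a carbonyl in place of the thiocarbonyl, as in compound 1.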